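A Silent Series and One Further Exchange

The compounds below may be only part of what the source reports. "The series", "measured", "known", "first", "only" and "open" are said of these compounds alone.

Of the compounds shown here, three built on one shared core have been measured in an assay on isolated protein for activation of cGMP-dependent protein kinase 1 (Homo sapiens), read by ADP-Glo, with stated times of 30 min and 2 h; a higher number here means that more compound is needed for the effect, a lower number that less compound is needed. Compound 1, `COc1cccc([C@@H](CO)O[C@H]2CCCN(Cc3ccc(C(=O)O)cc3C)[C@H]2c2ccccc2)c1`, gives > 200000 nM, which is a limit of the assay and not a number. Compound 3, `Cc1cc(C(=O)O)ccc1CN1CCC[C@H](O[C@H](CO)c2cc(F)cc(F)c2)[C@@H]1c1ccccc1`, likewise gives > 200000 nM, again only a limit. The step that the two limits leave unreadable from compound 1 to compound 3 is accordingly unreadable. Compound 2, `COC(=O)c1ccc(CN2CCC[C@H](O[C@H](CO)c3cc(Cl)cc(Cl)c3)[C@@H]2c2ccccc2)c(C)c1`, gives > 200000 nM, once more a limit; it stands exactly where the other two stand, since (the limit of > 200000 nM in this assay, at which 3 of the 3 values shown sit).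

Compound 4, `OC[C@@H](O[C@H]1CCCN(Cc2nc3ccccc3[nH]2)[C@H]1c1ccccc1)c1cc(Cl)cc(Cl)c1`, differs from compound 2 in a single place: a group of 9 heavy atoms (7 carbon, 2 nitrogen; one five-membered aromatic ring with 2 hetero atoms, one six-membered aromatic ring of carbon only) in place of a group of 11 heavy atoms (9 carbon, 2 oxygen; one six-membered aromatic ring of carbon only), on a saturated chain carbon bound to an amine nitrogen in a ring. Within the data shown here, no measured step touches this exchange, and the only measured step, a step that the two limits leave unreadable from compound 1 to compound 3, concerns a different place and is itself unreadable. What the three measured compounds do show is that variation at the saturated chain carbon bound to an oxygen on a saturated carbon and a saturated chain carbon leaves every value at the limit, so nothing here points toward a gain. The writer expects compound 4 to stay at or near that limit, with an at least 1.3-fold lower number from compound 2 to compound 4 (0.12 log units; that floor lies within the scatter) as the expected step, most likely no readable change beyond the scatter. Compound 4 is estimated at 150000 nM, within 20000 nM to 400000 nM.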

Compound 4, half-maximal effective concentration: > 200000 nM
Compound 4: only a limit was reported; the forecaster's own chance of this, stated with the estimate: 70%; at least 1.3-fold (0.12 log units) between middle value and limit.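

In this assay compound 4 gives > 200000 nM, which is a limit of the assay and not a number. No step can be read from compound 2 to compound 4, since both values are limits: the limit of > 200000 nM in this assay, at which 4 of the 4 values shown sit.

The compounds shown leave open how much compound any of the four would need for the effect, and which exchange on the shared core, if any, would bring a value within reach of this assay.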